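The source may hold more compounds than are shown below. What is called first, only, known or untested is meant among the compounds shown, and "the series" means these compounds.

Of the compounds shown here, three built on a shared core have been tested in a functional assay on A-375 cells (Homo sapiens) for antiproliferative activity, read by MTT assay, with a stated time of 24 h, tested at 0.14 ug/mL; a lower number here means a weaker effect, a higher number a stronger effect of the compound at the concentration tested. Compound 1 `Cc1ccc2nc(C(=O)Nc3c(F)cc(-c4cccc(F)c4)cc3F)c(C)c(O)c2c1` gives 1.06%. Compound 2 `CCc1ccc2nc(C(=O)Nc3c(F)cc(-c4cccc(F)c4)cc3F)c(C)c(O)c2c1` gives 1.57%, and compound 3 `CCOc1ccc2nc(C(=O)Nc3c(F)cc(-c4cccc(F)c4)cc3F)c(C)c(O)c2c1` gives 1.54%. The steps between them are small: a number 0.5 percentage points higher from compound 1 to compound 2 (within the scatter), a number 0.5 percentage points higher from compound 1 to compound 3 (within the scatter) and a number 0 percentage points lower from compound 2 to compound 3 (within the scatter). Compound 1 thus holds the lowest of the three numbers, but both others lie within the usual scatter of it, so no order among the three can be read from these data.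

Compound 4 `Cc1ccc2nc(C(=O)Nc3c(F)cc(-c4cccc(F)c4)cc3F)c(C)c(C(=O)O)c2c1` differs from compound 1 in one place: carboxy in place of hydroxy on an aromatic carbon. Within the data shown here, none of the measured steps concerns this change; the steps seen so far involve only methyl, ethyl and ethoxy groups elsewhere on the core, and all of them lie within the scatter. Among the measured compounds shown here, with no step bearing on the change, the expectation in this assay from compound 1 to compound 4 is one of no step beyond the scatter, estimated as a number 0.4 percentage points higher from compound 1 to compound 4 (within the scatter). Compound 4 is therefore expected to give 1.5%, within a range from 0% to 10%.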

Compound 4, a percentage reported as inhibition, at one concentration (the size of the read-out at that concentration, not a potency): 0.98%
Compound 4: the middle estimate sits 0.5 percentage points above what was measured, and the stated range covers the measured number.
By their numbers in this assay, from the lowest: compounds 4, 1, 3 and 2 (each within the scatter of the next).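

In this assay, carboxy in place of hydroxy, on the aromatic carbon opposite the ring nitrogen and ortho to the methyl group, gives a number 0.1 percentage points lower from compound 1 to compound 4 (within the scatter). Among these compounds, this is the first measured change at this position, as the earlier steps all lay elsewhere on the core, and it shows that exchanging hydroxy for the larger carboxy, with its double bond outside aromatic rings, moves the read-out no further than the scatter at the one concentration tested. No measurement shown offers an explanation for this result.

On these data alone, whether an amine, a methoxy group or a longer chain at this position would give a step beyond the scatter remains open. Also open, as far as these compounds go, is whether carboxy and hydroxy would still lie this close at another concentration.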